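The source may hold more compounds than are shown below. What is called first, only, known or untested is meant among the compounds shown, and "the series" means these compounds.

Of the compounds shown here, three of one series have been measured in a functional assay on HT-29 cells (Homo sapiens) for antiproliferative activity, read by MTT assay, with a stated time of 72 h; on this read-out higher numbers stand for weaker inhibition and lower numbers for stronger inhibition. Compound 1 `CN(C)CCn1cnnc1-c1cc(Oc2ccc(NC(=O)Nc3ccc(F)c(Cl)c3)cc2F)ccn1` gives 720 nM. Compound 2 `CCN(CC)CCn1cnnc1-c1cc(Oc2ccc(NC(=O)Nc3cccc(C(F)(F)F)c3)cc2F)ccn1` gives 630 nM. Compound 3 `CCN(CC)CCn1cnnc1-c1cc(Oc2ccc(NC(=O)Nc3ccc(F)c(F)c3)cc2F)ccn1` gives 1240 nM, the highest number of the three, although compound 1 and compound 2 both lie within the usual scatter of it. Among the measured compounds shown here, the only single-point step among them is a 2.0-fold higher number from compound 2 to compound 3 (0.29 log units; within the scatter), which exchanges one aryl group on the urea for another without leaving the scatter.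

Compound 4 `CCN(CC)CCn1cnnc1-c1cc(Oc2ccc(NC(=O)Nc3ccc(F)c(Cl)c3)cc2F)ccn1` differs from compound 3 by chloro in place of fluoro on an aromatic carbon. Compound 1 carries this same 3-chloro-4-fluorophenyl group on a core that differs elsewhere, so its value and that of compound 3 can be noted but do not form a step. Given that the aryl exchange in the measured step stayed within the scatter, a step of similar or smaller size, towards a lower number, is expected from compound 3 to compound 4: a 1.6-fold lower number from compound 3 to compound 4 (0.19 log units; within the scatter). Compound 4 is therefore estimated at 800 nM in this assay, with a range from 400 nM to 1600 nM.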

Compound 4, half-maximal inhibitory concentration: 500 nM
The estimate for compound 4 lay 1.6-fold (0.20 log units) above the measured number, and the stated range covers the measured number.
By their numbers in this assay, from the lowest: compounds 4, 2, 1 and 3 (each within the scatter of the next, the first and the last beyond it).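

In this assay, among the compounds shown here, the exchange of fluoro for chloro on an aromatic carbon, ortho to a fluoro group, gives a 2.5-fold lower number from compound 3 to compound 4 (0.39 log units; beyond the scatter) and so provides the first step to pass beyond the scatter, though only modestly. The other two comparisons stay within the scatter: replacing the 3-(trifluoromethyl)phenyl group with 3-chloro-4-fluorophenyl gives a 1.3-fold lower number from compound 2 to compound 4 (0.10 log units; within the scatter) while diethylamino in place of dimethylamino on the chain gives a 1.4-fold lower number from compound 1 to compound 4 (0.16 log units; within the scatter) and neither change separates the compounds. Nothing available here explains the chloro step.

As far as these compounds go, what a bromo or methyl group on this same aromatic carbon would give remains open. Also open, from the compounds shown here alone, are whether the chloro-for-fluoro step would hold with dimethylamino on the chain and what a pyrrolidine or morpholine at the chain end would give.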